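Opening the Oxetane: From Compound 2 to Compound 3

A few compounds are considered here, and "the series" means these few. Any claim that something is new, unique, unknown or untested is made for them only; others in the source may bear on it.

Measured so far:
compound 1, `CCN(Cc1ccsc1)C(=O)COc1ccc(C)cc1`: 88 nM
compound 2, `Cc1ccc(OCC(=O)N(Cc2cccs2)C2COC2)cc1`: 23000 nM

Of the two compounds measured, compound 2 stands highest: in an assay on HEK293 cells for agonist activity at transient receptor potential cation channel subfamily M member 8 (Homo sapiens), read by fluorescence and calcium flux, with a stated time of 15 min (a higher number here means that more compound is needed for the effect, a lower number that less compound is needed), compound 2 gives 23000 nM, whereas compound 1 gives 88 nM, a gap well beyond the usual scatter. Compound 3 is `Cc1ccc(OCC(=O)N(CCCO)Cc2cccs2)cc1`. It differs from compound 2 in a single place: 3-hydroxypropyl in place of oxetan-3-yl on an amide-type nitrogen. Among the measured compounds shown here, no measured pair shows this kind of change, so its size is uncertain; a modest drop in the number, somewhat beyond the scatter, is expected, a 3.8-fold lower number from compound 2 to compound 3 (0.58 log units; beyond the scatter). Compound 3 is therefore expected to give about 6000 nM, within a range from 1500 nM to 25000 nM.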

Compound 3, half-maximal effective concentration: 3000 nM
For compound 3 the middle estimate is 2.0-fold (0.30 log units) above the measured one, within the range that was stated.
By their numbers in this assay, from the lowest: compound 1; then compound 3; then compound 2.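

At the amide-type nitrogen, 3-hydroxypropyl in place of oxetan-3-yl lowers the number in this assay (a 7.7-fold lower number from compound 2 to compound 3 (0.88 log units; beyond the scatter)). The heavy-atom count stays the same, so this position responds even when the group keeps its size in atoms and only the ring gives way to an open chain with a hydrogen-bond donor. No measurement available here explains the step.

Still open, from the compounds shown here alone, is whether the open chain or its hydroxyl matters more. A plain propyl chain or a 3-aminopropyl group on the same nitrogen would help separate the two.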